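A few compounds are considered here, and "the series" means these few. Any claim that something is new, unique, unknown or untested is made for them only; others in the source may bear on it.

Measured so far in an assay on isolated protein (strain Sprague-Dawley) for inhibition of Amine oxidase [flavin-containing] B (Rattus norvegicus), read by spectrophotometry, with a stated time of 5 min; a lower number here means a stronger inhibitor, a higher number a weaker inhibitor:
compound 1 `COCOc1cc(=O)oc2cc(OCc3cccc(Cl)c3)ccc12` — 100 nM
compound 2 `CC(=O)COc1cc(=O)oc2cc(OCc3cccc(Cl)c3)ccc12` — 26.9 nM
compound 3 `O=c1cc(Nc2ccccc2)c2ccc(OCc3cccc(Cl)c3)cc2o1` — 9770 nM

Compound 3 gives the highest number of the three, with a 98-fold higher number from compound 1 to compound 3 (1.99 log units; beyond the scatter) and a 360-fold higher number from compound 2 to compound 3 (2.56 log units; beyond the scatter).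

Compound 4 `NC(=O)c1cc(=O)oc2cc(OCc3cccc(Cl)c3)ccc12` differs from compound 3 as follows: carbamoyl in place of anilino on an aromatic carbon. Among the measured compounds shown here, no measured step trades anilino for carbamoyl directly. The two steps that bear on it both introduce anilino and both are large, the smaller being a 98-fold higher number from compound 1 to compound 3 (1.99 log units; beyond the scatter) and the larger 360-fold higher number from compound 2 to compound 3 (2.56 log units; beyond the scatter); a step removing anilino for a group of 3 heavy atoms with no ring is therefore expected to lower the number by a large margin, though how far carbamoyl tracks the oxygen-linked groups is open. The estimate for compound 4 in this assay is 400 nM, range 60 nM to 3000 nM, expected as a 24-fold lower number from compound 3 to compound 4 (1.39 log units; beyond the scatter).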

Compound 4, half-maximal inhibitory concentration: 234 nM
For compound 4 the middle estimate is 1.7-fold (0.23 log units) above the measured one; the measured number falls inside the stated range.
By their numbers in this assay, from the lowest: compound 2; then compound 1; then compound 4; then compound 3.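

In this assay, a carbamoyl group with no ring, at the position opposite the ring oxygen, removes most of the penalty seen with anilino, with a 42-fold lower number from compound 3 to compound 4 (1.62 log units; beyond the scatter). Carbamoyl still falls short of both oxygen-linked groups, with a 2.3-fold higher number from compound 1 to compound 4 (0.37 log units; beyond the scatter) and an 8.7-fold higher number from compound 2 to compound 4 (0.94 log units; beyond the scatter), so among these four compounds the lowest numbers stay with those groups. The data offer no evidence on the reason for these differences.

Going by these compounds, whether ring loss, group size or the amide itself drives the drop stays open. A carboxylic acid, a primary amine or a benzamide-type group at this position would help separate these.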